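A pyridin-4-yl to 3-methylphenyl swap and its expected effect

The source may report more compounds than this note shows. Statements on the series, on what has been measured and on what is new or still open speak of the compounds shown alone.

Compound 1 `C(=C/c1nn2c(-c3ccncc3)nnc2s1)\c1ccco1` gives 82% in an assay for inhibition of histone-lysine N-methyltransferase, H3 lysine-79 specific (Homo sapiens), read by scintillation counting, with stated times of 15 min and 60 min, tested at 100 uM, in the presence of a further agent that is not named here (a lower number here means a weaker effect, a higher number a stronger effect of the compound at the concentration tested), the highest of the three numbers recorded. Compound 3 `c1ccc2c(Cc3nn4c(-c5ccoc5)nnc4s3)cccc2c1` gives 77%, within the scatter of compound 1, while compound 2 `Fc1cccc(-c2nnc3sc(CCc4ccccc4)nn23)c1` gives 50%, beyond it. Compound 4 `Cc1cccc(-c2nnc3sc(/C=C/c4ccco4)nn23)c1` differs from compound 1 by 3-methylphenyl in place of pyridin-4-yl on an aromatic carbon. Among the compounds with values here, no step between measured compounds isolates this change, and compound 2 and compound 3 each differ from compound 1 in more than one place, so their values are only a loose guide. Compound 2 gives 50% and carries a six-membered aromatic ring of carbon only, the one pointer available. On that basis a fall, probably beyond the scatter, is expected for the step of a number 14 percentage points lower from compound 1 to compound 4 (beyond the scatter). Compound 4 is therefore estimated at 68%, between 45% and 88%.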

Compound 4, a percentage reported as inhibition, at one concentration (the size of the read-out at that concentration, not a potency): 74%
Estimate against measurement, compound 4: 6 percentage points below, within the range that was stated.
By their numbers in this assay, from the lowest: compound 2; then compounds 4, 3 and 1 (each within the scatter of the next).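

In this assay, within the data shown here, 3-methylphenyl in place of pyridin-4-yl on the aromatic carbon gives a number 8 percentage points lower from compound 1 to compound 4 (within the scatter), the first direct reading of a change at this position. The group can thus lose its ring nitrogen, its one hydrogen-bond acceptor, without a change beyond the scatter at this single concentration. Nothing measured here accounts for this result.

The compounds shown leave open how an amine or a carboxylic acid on this six-membered ring would fare. They also leave open whether a saturated ring such as piperidine would be accepted at this place.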